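This account rests on a few compounds, and the source may have more. Where it says the series, first, only, none or still open, it means among the compounds named here.

Of the compounds shown here, three of one family have so far been tested for agonist activity in a functional assay on cells for agonist activity at C-X-C chemokine receptor type 4 (Homo sapiens), read by fluorescence and calcium flux, with a stated time of 90 s; a higher number here means that more compound is needed for the effect, a lower number that less compound is needed. Compound 1 `c1ccc(CN(CCCCN(C[C@H]2Cc3ccccc3CN2)[C@H]2CCCc3cccnc32)Cc2ccccn2)nc1` gives > 30000 nM in this assay, which is a limit of the assay and not a number. Compound 2 `c1ccc2c(c1)CN[C@@H](CN(CCCCN(Cc1ccncc1)Cc1ccncc1)[C@H]1CCCc3cccnc31)C2` likewise reaches only a limit, giving > 30000 nM in this assay. Compound 3 `c1ccc2c(c1)CN[C@@H](CN(CCCCNC1CCOCC1)[C@H]1CCCc3cccnc31)C2` gives > 30000 nM in this assay, again a limit rather than a number. All three values thus stand at the same place, described by the limit of > 30000 nM in this assay, at which 3 of the 3 values shown sit, so compound 3 cannot be set above or below compound 1 or compound 2 on the numbers shown; nothing in the set separates them.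

The next compound, compound 4 `CC(C)(N)CCCN(C[C@H]1Cc2ccccc2CN1)[C@H]1CCCc2cccnc21`, differs from compound 3 by a single change: 1-amino-1-methylethyl in place of ((oxan-4-yl)amino)methyl on a saturated chain carbon, three bonds along the chain from an amine nitrogen. Among the measured compounds shown here, no measured pair in this set isolates such a change, so there is no measured step to lean on. For the measured compounds named here, with every value so far sitting at a limit, the author expects the step of an at least 1.5-fold lower number from compound 3 to compound 4 (0.17 log units; that floor lies within the scatter) to be small or none beyond the scatter. On that basis compound 4 is estimated to give about 20000 nM in this assay, with a range from 3000 nM to 30000 nM, and it would not be surprising if the assay again returned only a limit.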

Compound 4, half-maximal effective concentration: > 30000 nM
Compound 4: no number, only a limit; the forecaster's own chance of this, stated with the estimate: 70%; at least 1.5-fold (0.17 log units) between middle value and limit.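

In this assay compound 4 gives > 30000 nM, which is a limit of the assay and not a number. Compound 3 also stands at a limit, so no step can be read from compound 3 to compound 4: the limit of > 30000 nM in this assay, at which 4 of the 4 values shown sit.

The compounds shown leave open whether any member of this family gives a measurable half-maximal effective concentration, and how their groups would rank.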